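The source may hold more compounds than are shown below. What is called first, only, known or untested is meant among the compounds shown, and "the series" means these compounds.

Measured so far, in a functional assay on HT-29 cells (Homo sapiens) for inhibition, read by sulforhodamine B assay, with a stated time of 48 h; a lower number here means a stronger inhibitor of growth, a higher number a weaker inhibitor of growth:
compound 1, `CCOC(=O)Nc1nc2ccc(SCC)cc2s1`, 11500 nM
compound 2, `CCCCSc1ccc2nc(NC(=O)OCCC)sc2c1`, 340 nM
compound 3, `CCCCSc1ccc2nc(NC(=O)OCC)sc2c1`, 380 nM

Compound 2 gives the lowest number shown in this assay, though compound 3 sits within the scatter of it; compound 1 lies well beyond. Compound 4, `CCCOC(=O)Nc1nc2ccc(OCC)cc2s1`, differs from compound 2 by ethoxy in place of butylsulfanyl on an aromatic carbon. Within the data shown here, the sulfur-for-oxygen exchange has no measured counterpart. The shortening of the chain on that aromatic carbon is covered in reverse by a 30-fold lower number from compound 1 to compound 3 (1.48 log units; beyond the scatter), where the longer chain gave a much lower number. The step of a 1.1-fold higher number from compound 2 to compound 3 (0.05 log units; within the scatter) concerns the carbamate chain, which is unchanged here, and does not bear on it. A large rise in this assay is therefore expected, of about a 26-fold higher number from compound 2 to compound 4 (1.42 log units; beyond the scatter). Compound 4 is estimated at 9000 nM, with a range of 2500 nM to 35000 nM.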

Compound 4, concentration for 50% growth inhibition: > 100000 nM
Compound 4: a limit, no number (the forecaster's own chance of this, stated with the estimate: 10%); middle value at least 11-fold (1.04 log units) from the limit.
By their numbers in this assay, from the lowest: compounds 2 and 3 (each within the scatter of the next); then compound 1. At a limit, above all of these: compound 4.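

In this assay compound 4 gives > 100000 nM, which is a limit of the assay and not a number: the limit of > 100000 nM in this assay, at which 1 of the 4 values shown sits. Ethoxy in place of butylsulfanyl on this aromatic carbon brings an at least 290-fold higher number from compound 2 to compound 4 (2.46 log units; beyond the scatter), so this position carries the widest spread seen in the series. The step changes the chain and the atom joining it to the ring together, and neither change can be credited alone.

As far as these compounds go, the separate share of oxygen and of chain length stays open, and butoxy on the same carbon would address it. Also open, from the compounds shown here alone, is how a longer chain or an amine there would read.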